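This account rests on a few compounds, and the source may have more. Where it says the series, first, only, none or still open, it means among the compounds named here.

Measured so far:
compound 2, `O=C(NCc1ccccc1)c1ccccc1-c1ccccc1`: 7500 nM
compound 1, `O=C(OCc1ccccc1-c1ccccc1)C1CCCN(CCCc2ccccc2)C1`: 17800 nM

In an in vitro functional assay on HEK ts201 cells for antagonist activity at Neuronal acetylcholine receptor; alpha4/beta2 (Homo sapiens), read by fluorescence and calcium flux (on this read-out higher numbers stand for weaker inhibition and lower numbers for stronger inhibition), compound 2 gives 7500 nM, the lowest of the two numbers. In this assay, among the compounds with values here, compound 1 gives 17800 nM, a gap that lies beyond the usual scatter; the two compounds differ in more than one place, so no single step between them is described. Compound 3, `O=C(Nc1ccncn1)c1ccccc1-c1ccccc1`, arises from compound 2 by one change: pyrimidin-4-yl in place of benzyl on an amide-type nitrogen. Within the data shown here, no step between measured compounds bears on this exchange, so its effect is an open question. The expected step, a 1.5-fold higher number from compound 2 to compound 3 (0.17 log units; within the scatter), is small, more likely toward a higher number than a lower one, and possibly not beyond the scatter. In this assay compound 3 is expected at 11000 nM, estimated to fall between 3500 nM and 35000 nM.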

Compound 3, half-maximal inhibitory concentration: 25100 nM
For compound 3 the middle estimate is 2.3-fold (0.36 log units) below the measured one; measured number inside the range.
By their numbers in this assay, from the lowest: compound 2; then compounds 1 and 3 (each within the scatter of the next).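

In this assay, pyrimidin-4-yl in place of benzyl on the amide-type nitrogen gives a 3.3-fold higher number from compound 2 to compound 3 (0.52 log units; beyond the scatter) and so moves the number beyond the scatter. This is the first comparison among the compounds shown that isolates a single place, and it shows that the read-out responds to the group on this nitrogen. The exchange replaces a six-membered aromatic ring of carbon only with one bearing 2 hetero atoms, but nothing measured here says why the number rises.

A single exchange cannot separate the effect of the ring's nitrogen atoms from that of losing the benzyl carbon chain. Going by these compounds, it remains open whether a plain phenyl or a pyridin-4-yl group on this nitrogen would give a number closer to compound 2 or to compound 3.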